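Step from 3-fluorophenyl to 4-fluorophenyl in a limit-bound series

The source may report more compounds than this note shows. Statements on the series, on what has been measured and on what is new or still open speak of the compounds shown alone.

In a functional assay on A549 cells (Homo sapiens) for antiproliferative activity, read by MTT assay, with a stated time of 72 h (a lower number here means a stronger inhibitor, a higher number a weaker inhibitor), compound 1 `COc1cc(-n2ncnc2-c2ccc(Cl)cc2)cc(OC)c1OC` gives > 10000 nM as a limit and not a number. Compound 2 `COc1cc(-n2ncnc2-c2cccc(F)c2)cc(OC)c1OC` gives > 10000 nM as a limit too, so it has no measured potency to start from. The step that the two limits leave unreadable from compound 1 to compound 2 has no readable size, and the limit of > 10000 nM in this assay, at which 2 of the 2 values shown sit, is all the series offers. Compound 3 `COc1cc(-n2ncnc2-c2ccc(F)cc2)cc(OC)c1OC` differs from compound 2 by the change 4-fluorophenyl in place of 3-fluorophenyl on an aromatic carbon on an aromatic carbon between two ring nitrogen atoms. Among the compounds with values here, with no sized step to carry over, no shift beyond the scatter is expected in this assay and no direction can be given. The estimated step that the limit leaves unreadable from compound 2 to compound 3 is expected to stay small. Compound 3 is expected at 12000 nM with an estimated range of 3000 nM to 40000 nM for this measurement.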

Compound 3, half-maximal inhibitory concentration: > 10000 nM
Compound 3 was reported as a limit; the forecaster's own chance of this, stated with the estimate: 75%; the middle value lies beyond the limit too.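

Within the data shown here, compound 3 gives > 10000 nM, again a limit and not a number, so no step among compound 1, compound 2 and compound 3 can be read: the limit of > 10000 nM in this assay, at which 3 of the 3 values shown sit. Going by these compounds, what swapping the fluoro or chloro phenyl group does to potency stays open.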